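This account rests on a few compounds, and the source may have more. Where it says the series, first, only, none or still open, it means among the compounds named here.

Three compounds carrying the same core share a seat on a functional assay for antagonist activity at metabotropic glutamate receptor 5 (Rattus norvegicus); on this read-out lower numbers stand for stronger inhibition and higher numbers for weaker inhibition. Compound 1 `N#Cc1ccccc1-c1cc(F)cc(-n2nnc(-c3ccccn3)n2)c1` gives 6 nM. Compound 2 `Nc1ccccc1-c1cc(F)cc(-n2nnc(-c3ccccn3)n2)c1` carries an amino group where compound 1 carries a nitrile. Compound 2 gives 8 nM, and the step of a 1.3-fold higher number from compound 1 to compound 2 (0.12 log units; within the scatter) is within the scatter. Compound 3 `Cc1ccc(-c2cc(F)cc(-n3nnc(-c4ccccn4)n3)c2)cn1` gives 57 nM, and the steps of a 9.5-fold higher number from compound 1 to compound 3 (0.98 log units; beyond the scatter) and a 7.1-fold higher number from compound 2 to compound 3 (0.85 log units; beyond the scatter) are both beyond the scatter. Compound 2 thus stands with the second highest number of the three, close to compound 1 and well apart from compound 3.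

Compound 4 `Nc1ccncc1-c1cc(F)cc(-n2nnc(-c3ccccn3)n2)c1` is not yet measured. It differs from compound 2 in one place: 4-aminopyridin-3-yl in place of 2-aminophenyl on an aromatic carbon. The measured step that bears most directly on this change is a 7.1-fold higher number from compound 2 to compound 3 (0.85 log units; beyond the scatter), where a pyridinyl group likewise replaced the 2-aminophenyl group; that step, however, also dropped the amino group and attached the ring differently, so it is only a loose guide. The step of a 1.3-fold higher number from compound 1 to compound 2 (0.12 log units; within the scatter) shows that the amino group itself leaves the number largely unchanged. On this basis a modest rise in the number, smaller than that seen in compound 3, is expected in this assay, as the estimated step of a 2.5-fold higher number from compound 2 to compound 4 (0.40 log units; beyond the scatter) expresses. Compound 4 is therefore expected to give 20 nM, with a range from 6 nM to 70 nM.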

Compound 4, half-maximal inhibitory concentration: 108 nM
Beside the measured number, compound 4's estimate is 5.4-fold (0.73 log units) below it; the whole stated range lies below it.
By their numbers in this assay, from the lowest: compounds 1 and 2 (each within the scatter of the next); then compounds 3 and 4 (each within the scatter of the next).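

In this assay, the trade of 2-aminophenyl for 4-aminopyridin-3-yl keeps the amino group and changes the ring to one with a nitrogen atom, yet it gives a large step (a 14-fold higher number from compound 2 to compound 4 (1.13 log units; beyond the scatter)), so the tolerance for the amino group seen earlier does not carry over to this new ring. Keeping an amino group on a pyridinyl ring also fails to separate the two pyridinyl compounds (a 1.9-fold higher number from compound 3 to compound 4 (0.28 log units; within the scatter), within the scatter), while the distance from the nitrile compound is also large (an 18-fold higher number from compound 1 to compound 4 (1.26 log units; beyond the scatter)), so at this position all four compounds fall into two pairs, the carbon-only rings of compounds 1 and 2 with the lower numbers and the pyridinyl rings of compounds 3 and 4 with the higher ones, and none goes against this. Nothing at hand accounts for this split between the two pairs.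

The compounds shown leave open whether the loss follows the ring nitrogen wherever it stands, as a 2-aminopyridin-3-yl group would test. They also leave open whether a pyridinyl ring carrying a nitrile, or a phenyl ring carrying a methyl group, would side with the lower or the higher pair.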